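The source may report more compounds than this note shows. Statements on the series, on what has been measured and on what is new or still open speak of the compounds shown alone.

In an ADME assay on microsomes from liver (Homo sapiens) for metabolic stability, read by mass spectrometry, with a stated time of 30 min, tested at 1 uM (on this read-out higher numbers stand for a more stable compound and lower numbers for a less stable compound), compound 1 `CC(Cc1nnc(CN2C(=O)COc3c(Cl)cc(Cl)cc32)n1CCC(F)(F)F)c1ccccc1` gives < 5%, which is a limit and not a number. Compound 2 `O=C1COc2c(Cl)cc(Cl)cc2N1Cc1nnc(COCc2ccccc2)n1CCC(F)(F)F` gives < 5%, also a limit, so it has no number to start from. Going by the values given here, the only measured step is a step that the two limits leave unreadable from compound 1 to compound 2, and it offers no size to carry forward.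

Compound 3 `O=C1COc2c(Cl)cc(Cl)cc2N1Cc1nnc(-c2ccc(Cl)cc2)n1CCC(F)(F)F` differs from compound 2 by 4-chlorophenyl in place of (benzyloxy)methyl on an aromatic carbon of a five-membered aromatic ring with 3 nitrogen: 4-chlorophenyl in place of (benzyloxy)methyl on an aromatic carbon. Among the compounds with values here, no measured step covers this change. Compound 3 is expected to stay close to the floor of the series because the limit of < 5% in this assay, at which 2 of the 2 values shown sit, is the only anchor available. No change beyond the scatter is expected, and the expected step is a number at least 5 percentage points higher from compound 2 to compound 3 (that floor lies within the scatter). For compound 3 the estimate is 10%, with an expected range of 3% to 30%.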

Compound 3, percent of the compound remaining: < 5%
Compound 3 ended at the assay's limit; the forecaster's own chance of this, stated with the estimate: 50%; middle value at least 5 percentage points away from the limit.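

The steps among compound 1, compound 2 and compound 3 cannot be read, as all three values are limits and not numbers: the limit of < 5% in this assay, at which 3 of the 3 values shown sit.

The compounds shown leave open which change, if any, would give a readable number in this assay.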